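This account rests on a few compounds, and the source may have more. Where it says the series, first, only, none or still open, it means among the compounds named here.

Working notes on the series. Compound 1 `O=C(/C=C/c1ccc2c(c1)B(O)OC2)c1cccs1` and compound 2 `CCOC(=O)c1ccc(C(=O)/C=C/c2ccc3c(c2)B(O)OC3)cc1` share a core and differ only in the group attached to the carbonyl carbon. In a toxicity assay on MCF-10A cells (Homo sapiens) for cytotoxicity, read by MTT assay, with a stated time of 48 h (on this read-out lower numbers stand for stronger inhibition and higher numbers for weaker inhibition), compound 1 gives 13800 nM, the highest of the two numbers recorded so far, and in this assay compound 2 gives 12900 nM; the gap between them lies within the scatter, so no order can be read from it. Compound 3 `O=C(/C=C/c1ccc2c(c1)B(O)OC2)c1cccc(O)c1` has not yet been measured in this assay. Against compound 1 the change is 3-hydroxyphenyl in place of thiophen-2-yl on a carbonyl carbon. Among the compounds with values here, no measured pair covers this change, so the expectation rests on the two values alone, which sit close to each other even though the groups on the carbonyl carbon differ. The expected step is a 1.1-fold lower number from compound 1 to compound 3 (0.03 log units; within the scatter), in no direction beyond the scatter. Compound 3 is accordingly estimated at 13000 nM, with a range from 6000 nM to 28000 nM.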

Compound 3, half-maximal inhibitory concentration: 25300 nM
The estimate for compound 3 lay 1.9-fold (0.29 log units) below the measured number; the range from low to high includes it.
By their numbers in this assay, from the lowest: compounds 2, 1 and 3 (each within the scatter of the next).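

In this assay, the change of thiophen-2-yl to 3-hydroxyphenyl on a carbonyl carbon now has a measured step of its own (a 1.8-fold higher number from compound 1 to compound 3 (0.26 log units; within the scatter)), the first for this place in the series. A six-membered aromatic ring of carbon only, bearing a hydroxy group, can therefore take the place of a five-membered aromatic ring with one sulfur atom without the number moving beyond the scatter. No measurement is available that bears on this step, and no cause can be given for it.

Still open, on these data alone, is whether the ring or the hydroxy group accounts for any part of this step, which a plain phenyl group at this carbon would help to separate. Also open, as far as these compounds go, is whether a group of another kind there, such as an amine or a carboxylic acid, would move the number beyond the scatter.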